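Moving from a fluorobenzyl to a methoxyphenyl amide

The source may hold more compounds than are shown below. What is called first, only, known or untested is meant among the compounds shown, and "the series" means these compounds.

Of the compounds shown here, three sharing one core have been tested in an ADME assay on HepG2 2.2.15 cells (Homo sapiens) for cytotoxicity, read by MTT assay, with stated times of 48 h and 9 days; a lower number here means that less compound is tolerated, a higher number that more compound is tolerated. Compound 1 `COc1ccc2c(=O)c(/C=C/C(=O)Nc3ccc(C)cc3)coc2c1` gives 979000 nM, compound 2 `COc1ccc2c(=O)c(/C=C/C(=O)NCc3cccc(F)c3)coc2c1` gives 475000 nM, and compound 3 `COc1ccc2c(=O)c(/C=C/C(=O)NCc3ccccc3F)coc2c1` gives 146000 nM. Compound 3 thus stands lowest of the three, with a 6.7-fold lower number from compound 1 to compound 3 (0.83 log units; beyond the scatter) and a 3.3-fold lower number from compound 2 to compound 3 (0.51 log units; beyond the scatter); the remaining step is a 2.1-fold lower number from compound 1 to compound 2 (0.31 log units; beyond the scatter).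

Compound 4 `COc1ccc2c(=O)c(/C=C/C(=O)Nc3ccccc3OC)coc2c1` is the next candidate. The change is 2-methoxyphenyl in place of 2-fluorobenzyl on an amide-type nitrogen. Compound 4, like compound 1, carries its aromatic ring directly on the amide-type nitrogen, and both measured steps that removed such a ring in favour of a benzyl group lowered the number, namely a 2.1-fold lower number from compound 1 to compound 2 (0.31 log units; beyond the scatter) and a 6.7-fold lower number from compound 1 to compound 3 (0.83 log units; beyond the scatter). Among the compounds with values here, no measured pair tests a methoxy group, so the size is uncertain, but a rise beyond the scatter is expected, roughly a 3.4-fold higher number from compound 3 to compound 4 (0.53 log units; beyond the scatter). For compound 4 the estimated value in this assay is 500000 nM, within a range from 150000 nM to 1500000 nM.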

Compound 4, half-maximal cytotoxic concentration: 1050000 nM
Compound 4: middle estimate off by 2.1-fold (0.32 log units), on the low side; low and high end bracket the measured number.
By their numbers in this assay, from the lowest: compound 3; then compound 2; then compounds 1 and 4 (each within the scatter of the next).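

In this assay, the 2-methoxyphenyl group on the amide-type nitrogen gives a 7.2-fold higher number from compound 3 to compound 4 (0.86 log units; beyond the scatter) and a 2.2-fold higher number from compound 2 to compound 4 (0.34 log units; beyond the scatter), so compound 4 stands above both fluorobenzyl compounds. Against the other ring placed directly on that nitrogen, the step is a 1.1-fold higher number from compound 1 to compound 4 (0.03 log units; within the scatter), which leaves 2-methoxyphenyl and 4-methylphenyl level here, and among these four compounds, both with a directly attached ring stand above both with a benzyl group, with none going against this. Nothing available explains why the numbers move this way.

In compounds 3 and 4, the link to the ring and the group on the ring change together, and a 2-methoxybenzyl group would help separate those two changes. From the compounds shown here alone, how a ring carrying an amine or a carboxylic acid would behave at this position also stays open.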